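Hydroxy for dimethylamino on the saturated core

A few compounds are considered here, and "the series" means these few. Any claim that something is new, unique, unknown or untested is made for them only; others in the source may bear on it.

Of the compounds shown here, three have numbers so far. Compound 1 `COc1ccc2c(c1)CC/C(=C\c1ccccc1Br)C2=O` gives 100000 nM in an assay on mitochondria for inhibition of 1,25-dihydroxyvitamin D(3) 24-hydroxylase, mitochondrial (Rattus norvegicus); a lower number here means a stronger inhibitor, a higher number a weaker inhibitor. Compound 2 `COc1ccc2c(c1)CC/C(=C\c1ccc(O)cc1)C2=O` reaches only the limit of > 20000 nM in this assay. Compound 3 `CN(C)c1ccc(CC2CCc3cc(O)ccc3C2=O)cc1` gives 18000 nM in this assay, the lowest of the two numbers; the nearest is compound 1, which sits a clear distance higher. Within the data shown here, the only single-place step, a step that the limit leaves unreadable from compound 1 to compound 2, cannot be read, because the limit of > 20000 nM in this assay, at which 1 of the 3 values shown sits, hides its size.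

Compound 4 `O=C1c2ccc(O)cc2CCC1Cc1ccc(O)cc1` differs from compound 3 in one place: hydroxy in place of dimethylamino on an aromatic carbon. Among the measured compounds shown here, no measured step bears on this exact change. Compound 2, the other hydroxyphenyl compound, carries its group on a different core and shows only a limit. With nothing readable to lean on, compound 4 is expected to lose rather than gain, and a step of a 1.7-fold higher number from compound 3 to compound 4 (0.22 log units; within the scatter) is estimated. Compound 4 is therefore estimated at 30000 nM, within 8000 nM to 100000 nM, with a fair chance that this assay reports only a limit.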

Compound 4, half-maximal inhibitory concentration: 8900 nM
Beside the measured number, compound 4's estimate is 3.4-fold (0.53 log units) above it; the range from low to high includes it.
By their numbers in this assay, from the lowest: compound 4; then compound 3; then compound 1.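

In this assay, a 2.0-fold lower number from compound 3 to compound 4 (0.31 log units; beyond the scatter) is the first readable single-place step among the compounds shown, and it gives this aromatic carbon, para to a large group, its first direction: hydroxy in place of dimethylamino lowers the number rather than raising it. The step is modest, but it lies beyond the usual scatter, so dimethylamino is not needed at this position for the activity seen with compound 3. No measured property among the data shown accounts for the step.

As far as these compounds go, whether an amine with fewer carbons, a methoxy or a carboxylic acid on this same aromatic carbon would move the number further stays open. Compound 2 gives > 20000 nM, a limit of the assay and not a number, so it leaves open how a hydroxyphenyl group fares on its different core.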